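Thiophen-2-yl in Place of Phenyl, Measured Once and Expected Again

The source may hold more compounds than are shown below. What is called first, only, known or untested is meant among the compounds shown, and "the series" means these compounds.

Compound 1, `CN1CCN(c2ccc(Nc3ncc(/N=C/c4ccccc4)c(NC4CCCC4)n3)cc2)CC1`, gives 28600 nM in a functional assay on HT-29 cells (Homo sapiens) for antiproliferative activity, read by MTT assay; on this read-out lower numbers stand for stronger inhibition and higher numbers for weaker inhibition.
Compound 2, `CN1CCN(c2ccc(Nc3ncc(/N=C/c4cccs4)c(NC4CCCC4)n3)cc2)CC1`, gives 21700 nM in this assay.
Compound 3, `CC(C)Nc1nc(Nc2ccc(S(N)(=O)=O)cc2)ncc1/N=C/c1ccccc1`, gives 98200 nM in this assay.

Compounds 1 and 2 share one core and differ in a single place: thiophen-2-yl in place of phenyl on a carbon with a double bond to nitrogen. That change made a 1.3-fold lower number from compound 1 to compound 2 (0.12 log units; within the scatter), so the two numbers stand within the usual scatter of each other and nothing can be said about which of them is the stronger inhibitor.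

Compound 3 is built on a different core, and the difference between the two cores is not broken down here. In this assay compound 3 gives the highest of the three numbers, and its steps to compound 1 and to compound 2 both lie beyond the scatter, so it is the weakest inhibitor among the measured compounds.

Compound 4, `CC(C)Nc1nc(Nc2ccc(S(N)(=O)=O)cc2)ncc1/N=C/c1cccs1`, has not yet been measured. It differs from compound 3 in the same way that compound 2 differs from compound 1: thiophen-2-yl in place of phenyl on a carbon with a double bond to nitrogen, the place being the same word for word in both pairs, so this is the same change. Because the same change made only a 1.3-fold lower number from compound 1 to compound 2 (0.12 log units; within the scatter), the step from compound 3 to compound 4 is expected to be of similar size, within the scatter, at about a 1.3-fold lower number from compound 3 to compound 4 (0.12 log units; within the scatter). Compound 4 is therefore estimated to give 75000 nM in this assay, with the expected range running from 40000 nM to 150000 nM.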

Compound 4, half-maximal inhibitory concentration: > 100000 nM
Compound 4: only a limit was reported; the forecaster's own chance of this, stated with the estimate: 10%; middle value at least 1.3-fold (0.12 log units) away from the limit.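

Compound 4 gives > 100000 nM in this assay, and this is a limit of the assay and not a number: the limit of > 100000 nM in this assay, at which 1 of the 4 values shown sits.

On these data alone, the step on this core can therefore be read only as a floor, an at least 1.0-fold higher number from compound 3 to compound 4 (0.00 log units; that floor lies within the scatter), so thiophen-2-yl in place of phenyl gave no step beyond the scatter on the core of compound 1, while on the core of compound 3 the size of the step stays unknown. Set beside each other, the two steps neither show that the change carries over from one core to the other nor show that it fails to do so: the same change on two cores in this assay, a 1.3-fold lower number (0.12 log units; within the scatter) from compound 1 to compound 2 and an at least 1.0-fold higher number (0.00 log units; that floor lies within the scatter) from compound 3 to compound 4; the limit leaves it open whether they differ.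

The compounds shown leave open how far the true reading of compound 4 lies from its limit, and with it how large the step on the core of compound 3 really is. They also leave open how a furan-2-yl or pyridin-2-yl group in the same place on either core would read, and whether an amine or a carboxylic acid on a longer chain there would bring the numbers on the core of compound 3 away from the limit.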